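Swapping a propynyl for a vinyl group on a nucleoside

This account rests on a few compounds, and the source may have more. Where it says the series, first, only, none or still open, it means among the compounds named here.

compound 1 `CC#C[C@@]1(O)[C@@H](CO)O[C@@H](n2ccc(N)nc2=O)[C@@H]1O`: 13900 nM
compound 2 `C#C[C@@H]1[C@@H](O)[C@H](n2ccc(N)nc2=O)O[C@@H]1CO`: > 30000 nM, a limit of the assay rather than a number

For the measured compounds named here, in a functional assay on Sarcoma-180 cells (Mus musculus) for cytotoxicity (a lower number here means a stronger inhibitor, a higher number a weaker inhibitor), compound 1 gives 13900 nM, the only measured number in this set. Compound 2 sits at the limit of > 30000 nM in this assay, at which 1 of the 2 values shown sits, so it offers no number. Compound 3 `C=C[C@@]1(O)[C@@H](CO)O[C@@H](n2ccc(N)nc2=O)[C@@H]1O` keeps the core of compound 1 with one change: vinyl in place of prop-1-yn-1-yl on a saturated ring carbon. Going by the values given here, no step between two measured compounds is available to calibrate this change, so the expected step of a 1.1-fold higher number from compound 1 to compound 3 (0.03 log units; within the scatter) is taken as small, no larger than the scatter, in no firm direction. Compound 3 is therefore estimated at 15000 nM, within a range of 5000 nM to 45000 nM.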

Compound 3, half-maximal inhibitory concentration: > 30000 nM
Compound 3 gave a limit, no number; the forecaster's own chance of this, stated with the estimate: 30%; at least 2.0-fold (0.30 log units) between middle value and limit.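

At this saturated ring carbon, the change is not neutral: vinyl in place of prop-1-yn-1-yl gives an at least 2.1-fold higher number from compound 1 to compound 3 (0.33 log units; beyond the scatter) in this assay. That step is only a lower bound, and the true gap could be much larger, since compound 3 has no number, only a limit of the assay. This limit also marks the edge of what the assay can separate here: the limit of > 30000 nM in this assay, at which 2 of the 3 values shown sit.

From the compounds shown here alone, what a plain ethyl group, a longer chain or an amine on this ring carbon would give remains open. The limit also leaves open how far compound 3 falls behind compound 1.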